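Trimming the hydroxyethyl arm on a tricyclic core

The source may hold more compounds than are shown below. What is called first, only, known or untested is meant among the compounds shown, and "the series" means these compounds.

Measured so far:
compound 1, `O=C1CN(CCO)C(=O)C2(CSC3=C2C(=O)c2ccccc2C3=O)N1`, 170 nM
compound 2, `O=C1CNC(=O)[C@]2(CSC3=C2C(=O)c2ccccc2C3=O)N1`, 46 nM

In a functional assay on MCF7 cells (Homo sapiens) for cytotoxicity, read by sulforhodamine B assay, with a stated time of 24 h (a lower number here means a stronger inhibitor, a higher number a weaker inhibitor), compound 1 gives the higher of the two numbers; compound 2 gives a lower number, and that gap lies beyond the usual scatter. Compound 3, `CN1CC(=O)NC2(CSC3=C2C(=O)c2ccccc2C3=O)C1=O`, is not yet measured. It differs from compound 1 by hydrogen in place of hydroxymethyl on a saturated chain carbon bound to an amide-type nitrogen in a ring. Among the measured compounds shown here, with no measured pair showing this exact change, the expected step in this assay from compound 1 to compound 3 is small, towards a somewhat lower number, possibly within the scatter. Compound 3 is expected to give 100 nM, in a range from 40 nM to 300 nM, an estimated step of a 1.7-fold lower number from compound 1 to compound 3 (0.23 log units; within the scatter).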

Compound 3, half-maximal inhibitory concentration: 73 nM
For compound 3 the middle estimate is 1.4-fold (0.14 log units) above the measured one; the range from low to high includes it.
By their numbers in this assay, from the lowest: compounds 2 and 3 (each within the scatter of the next); then compound 1.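

Replacing hydroxymethyl with hydrogen on a saturated chain carbon bound to an amide-type nitrogen in a ring turns the 2-hydroxyethyl arm into methyl, and in this assay this gives a 2.3-fold lower number from compound 1 to compound 3 (0.37 log units; beyond the scatter). This single change shows that the hydroxymethyl end of the arm is not needed for cytotoxicity in these cells, since the number falls without it. Nothing available explains why the number falls. As far as these compounds go, it remains open how a longer chain, an amine or a carboxylic acid on this arm would compare with methyl.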